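The source may hold more compounds than are shown below. What is called first, only, known or untested is meant among the compounds shown, and "the series" means these compounds.

In a functional assay on WM164 cells (Homo sapiens) for antiproliferative activity, read by sulforhodamine B assay, with a stated time of 48 h (on this read-out higher numbers stand for weaker inhibition and lower numbers for stronger inhibition), compound 1 `CCCCCCCCCCNC(=O)[C@@H]1CSC(c2cc(OC)c(OC)c(OC)c2)N1` gives 2100 nM, while compound 2 `CCCCCCCCCCNC(=O)[C@@H]1CSC(c2ccc(OC)c(OC)c2)N1` gives 6100 nM, the higher of the two numbers and so the weaker inhibition. Compound 3 `CCCCCCCCCCCCCCNC(=O)[C@@H]1CSC(c2ccc(OC)c(OC)c2)N1` keeps the aromatic substituents of compound 2 and differs only in the chain: butyl in place of hydrogen on a saturated chain carbon, ten or more bonds along the chain from an amide-type nitrogen. For the measured compounds named here, the only measured step is a 2.9-fold higher number from compound 1 to compound 2 (0.46 log units; beyond the scatter), a modest change beyond the scatter, with hydrogen in place of methoxy on an aromatic carbon. That step lies away from the chain, so no measurement tests the chain change directly, and it offers only a sense of scale. A modest step is therefore expected in this assay, tentatively towards a lower number, although the data fix no direction. The expected change is a 1.7-fold lower number from compound 2 to compound 3 (0.24 log units; within the scatter). For compound 3, the estimated value is 3500 nM, with an expected range from 1200 nM to 9000 nM.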

Compound 3, half-maximal inhibitory concentration: 800 nM
Compound 3: middle estimate off by 4.4-fold (0.64 log units), on the high side; the whole stated range lies above it.
By their numbers in this assay, from the lowest: compound 3; then compound 1; then compound 2.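

In this assay, the chain proves to be a second place where the number can move, since the earlier step concerned only the aromatic substituents. Butyl in place of hydrogen on a saturated chain carbon gives a 7.6-fold lower number from compound 2 to compound 3 (0.88 log units; beyond the scatter), which fixes the direction of this change towards stronger inhibition, at least with the aromatic substituents of compound 2. The data shown offer no measurement that would account for this step.

From the compounds shown here alone, whether a longer chain, or an amine or a carboxylic acid in place of the butyl, would move the number the same way remains open. Going by these compounds, it is also open whether the butyl would act in the same way alongside the additional methoxy group of compound 1.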